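This account rests on a few compounds, and the source may have more. Where it says the series, first, only, none or still open, it means among the compounds named here.

In a functional assay on NCI/ADR-RES cells (Homo sapiens) for antiproliferative activity (on this read-out higher numbers stand for weaker inhibition of growth and lower numbers for stronger inhibition of growth), the measured compounds are:

- compound 1 `CC/C=C\[C@H](C)[C@H](OC(N)=O)[C@@H](C)[C@H](O)[C@@H](C)C/C(C)=C\[C@H](C)[C@@H](O)[C@@H](C)/C=C\[C@@H](O)C[C@@H]1OC(=O)[C@H](C)C[C@H]1C`: 140 nM
- compound 2 `CC/C=C\[C@H](C)[C@H](OC(N)=O)[C@@H](C)[C@H](O)[C@@H](C)C/C(C)=C\[C@H](C)[C@@H](O)[C@@H](C)/C=C\[C@@H](O)C[C@@H]1OC(=O)[C@H](C)[C@@H](O)[C@H]1C`: 190 nM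

Compound 1 and compound 2 lie within the scatter of each other, so neither stands apart. Compound 3 `CC/C=C\[C@H](C)[C@H](OC(N)=O)[C@@H](C)[C@H](O)[C@@H](C)C/C(C)=C\[C@H](C)[C@@H](O)[C@@H](C)/C=C\[C@H](O)C[C@@H]1CCC(=O)O1` is unmeasured and differs from compound 1 as follows: a group of 9 heavy atoms (6 carbon, 3 oxygen; one five-membered non-aromatic ring with 1 hetero atom) in place of a group of 12 heavy atoms (9 carbon, 3 oxygen; one six-membered non-aromatic ring with 1 hetero atom), on a double-bonded chain carbon bound to a double-bonded chain carbon. Among the compounds with values here, the only measured step, a 1.4-fold higher number from compound 1 to compound 2 (0.13 log units; within the scatter), alters the group that leaves here, but far more modestly, and it stays within the scatter. It therefore offers only weak guidance, and the data do not fix the size of the new step. A higher number, meaning weaker inhibition of growth, is nevertheless expected. The expected step is a 5.0-fold higher number from compound 1 to compound 3 (0.70 log units; beyond the scatter). For compound 3 the estimated value is 700 nM, with an expected range of 200 nM to 3000 nM.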

Compound 3, concentration for 50% growth inhibition: 10000 nM
Estimate against measurement, compound 3: 14-fold (1.15 log units) below; the measured number lies above the stated range.
By their numbers in this assay, from the lowest: compounds 1 and 2 (each within the scatter of the next); then compound 3.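

In this assay this place proves sensitive: the change of ring-bearing group gives a 71-fold higher number from compound 1 to compound 3 (1.85 log units; beyond the scatter) and so goes well beyond the earlier hydroxy step, which gave a 1.4-fold higher number from compound 1 to compound 2 (0.13 log units; within the scatter) and stayed within the scatter. The hydrogen-bond donor and acceptor counts stay the same across the new step, so those counts alone do not track the loss of growth inhibition. Nothing available accounts for this loss.

The step changes ring size, carbon count and defined stereocentres together, so the compounds shown cannot separate them. As far as these compounds go, how an amine or a longer chain at this place would read also remains open.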